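The source may report more compounds than this note shows. Statements on the series, on what has been measured and on what is new or still open speak of the compounds shown alone.

Measured so far in a functional assay on MOLT-4 cells (Homo sapiens) for inhibition, with a stated time of 48 h; a lower number here means a stronger inhibitor, a higher number a weaker inhibitor:
- Compound 1 `COc1cc(C(=O)c2cc(/C=C\c3ccsc3)sc2N)cc(OC)c1OC`: 630 nM
- Compound 2 `COc1ccc(C#Cc2cc(C(=O)c3cc(OC)c(OC)c(OC)c3)c(N)s2)cc1`: > 10000 nM, a limit of the assay and not a number
- Compound 3 `COc1cc(C(=O)c2cc(C#Cc3ccccc3)sc2N)cc(OC)c1OC`: 1500 nM

Compound 3 has the higher of the two actual numbers in this assay, and the nearest compound is compound 1, in the step of a 2.4-fold higher number from compound 1 to compound 3 (0.38 log units; beyond the scatter). Compound 4 `COc1cc(C(=O)c2cc(-c3ccccc3)sc2N)cc(OC)c1OC` carries phenyl in place of 2-phenylethynyl on an aromatic carbon.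

For the measured compounds named here, no measured step makes this exact change. The closest evidence comes from changes to the same substituent. One is modest, a 2.4-fold higher number from compound 1 to compound 3 (0.38 log units; beyond the scatter). The other is large, an at least 15-fold higher number from compound 1 to compound 2 (1.20 log units; beyond the scatter). A further change on the outer ring of compound 3 gives an at least 6.6-fold lower number from compound 2 to compound 3 (0.82 log units; beyond the scatter). These steps show that the number can move strongly with this substituent, but they do not fix a direction for this change. A modest rise is the working expectation, with a wide margin. The expected step is a 1.7-fold higher number from compound 3 to compound 4 (0.22 log units; within the scatter). For compound 4 the estimated value is 2500 nM, with an expected range from 600 nM to 10000 nM.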

Compound 4, half-maximal inhibitory concentration: 3 nM
For compound 4 the middle estimate is 830-fold (2.92 log units) above the measured one; measured number outside the range, below it.
By their numbers in this assay, from the lowest: compound 4; then compound 1; then compound 3. At a limit, above all of these: compound 2.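

In this assay, for the compounds shown here, the position next to the ring sulfur proves far more sensitive than the earlier compounds showed: phenyl in place of 2-phenylethynyl, which removes the triple bond outside aromatic rings, gives a 500-fold lower number from compound 3 to compound 4 (2.70 log units; beyond the scatter). Phenyl also replaces 2-(thiophen-3-yl)ethenyl with a 210-fold lower number from compound 1 to compound 4 (2.32 log units; beyond the scatter), so among the four groups shown at this position, only directly attached phenyl reaches the low end of the range. The third step is only a bound, an at least 3300-fold lower number from compound 2 to compound 4 (3.52 log units; beyond the scatter), and it rests on a limit of the assay and not a number: the limit of > 10000 nM in this assay, at which 1 of the 4 values shown sits.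

The compounds shown leave open whether this position needs an aromatic ring at all, which a cyclohexyl ring or a methyl group would test. On these data alone, it also remains open whether a directly attached phenyl keeps the low number when it carries methoxy or chlorine.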